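This account rests on a few compounds, and the source may have more. Where it says the series, first, only, none or still open, it means among the compounds named here.

The series is followed in a functional assay on SH-SY5Y cells (Homo sapiens) for cytotoxicity, read by MTT assay, with stated times of 24 h and 4 h; on this read-out lower numbers stand for an effect already at smaller amounts and higher numbers for an effect only at larger amounts of compound. Compound 1 `COc1cc(CNC(=O)/C=C/c2ccccc2OCc2nc(C)c(C)nc2C)ccc1OCc1nc(C)c(C)nc1C` carries two (3,5,6-trimethylpyrazin-2-yl)methyl groups and in this assay compound 1 gives 6280 nM. Compound 2 `COc1cc(CNC(=O)/C=C/c2ccc(OCc3nc(C)c(C)nc3C)cc2)ccc1O` keeps one such group and leaves a free hydroxy; in this assay compound 2 gives 5370 nM. Of the two numbers on record that of compound 2 is the smaller one, but the gap to compound 1 lies within the usual scatter of repeated measurements, so the two compounds cannot be ranked against each other.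

Compound 3 `COc1cc(CNC(=O)/C=C/c2ccc(OCc3nc(C)c(C)nc3C)cc2)ccc1OCc1nc(C)c(C)nc1C` arises from compound 2 by a single change: (3,5,6-trimethylpyrazin-2-yl)methyl in place of hydrogen on an oxygen on an aromatic ring. For the measured compounds named here, no step between two measured compounds records what this change does on its own. What the record does show is that compound 1, which carries two of these groups, and compound 2, which carries one, sit within the scatter of each other, so the expected step from compound 2 to compound 3 is small, a 1.1-fold higher number from compound 2 to compound 3 (0.05 log units; within the scatter), with no direction beyond the scatter. On that basis compound 3 is expected to give about 6000 nM in this assay, within a range from 3000 nM to 12000 nM.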

Compound 3, half-maximal effective concentration: 7770 nM
The estimate for compound 3 lay 1.3-fold (0.11 log units) below the measured number; the range from low to high includes it.
By their numbers in this assay, from the lowest: compounds 2, 1 and 3 (each within the scatter of the next).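

For the compounds shown here, with compound 3, the effect of this change on its own can be read for the first time: in this assay, placing (3,5,6-trimethylpyrazin-2-yl)methyl in place of hydrogen on an oxygen on an aromatic ring gives a 1.4-fold higher number from compound 2 to compound 3 (0.16 log units; within the scatter) as the step. The step lies within the scatter, so the hydroxy of compound 2 and the (3,5,6-trimethylpyrazin-2-yl)methoxy of compound 3 cannot be told apart in this assay, and at this position the read-out does not separate a free hydroxy from this much larger group. No measurement on record offers an explanation for this result.

From the compounds shown here alone, what remains open is whether any other group on this oxygen, such as a simple methyl, a longer alkyl chain, an amine or a carboxylic acid, would give a number beyond the scatter from that of compound 2. Going by these compounds alone, the single step also leaves open whether the same exchange would give a similar result on a different core.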